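The source may report more compounds than this note shows. Statements on the series, on what has been measured and on what is new or still open speak of the compounds shown alone.

Measured in a functional assay on FM3A cells (Mus musculus) for antiproliferative activity, with a stated time of 48 h; on this read-out higher numbers stand for weaker inhibition and lower numbers for stronger inhibition:
compound 1 `C=C(Br)C(=O)Nc1ccc(/C=C/C(=O)c2ccc(F)cc2)cc1`: 1200 nM
compound 2 `C=C(Br)C(=O)Nc1ccc(/C=C/C(=O)c2cc(OC)c(OC)c(OC)c2)cc1`: 950 nM
compound 3 `Nc1ccc(/C=C/C(=O)c2ccc(F)cc2)cc1`: 185000 nM

Compound 3 stands at 185000 nM and has the highest number of the three, beyond the scatter from both compound 1 and compound 2. The next compound, compound 4 `Cc1ccc(C(=O)/C=C/c2ccc(N)cc2)cc1`, has not yet been measured. It differs from compound 3 by methyl in place of fluoro on an aromatic carbon, para to a large group: methyl in place of fluoro on an aromatic carbon.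

For the measured compounds named here, the one measured step, a 150-fold higher number from compound 1 to compound 3 (2.19 log units; beyond the scatter), is large, but it comes with hydrogen in place of (1-bromoethenyl)carbonyl on a nitrogen on an aromatic ring. That is a different place from the one changing here, so it gives no direct guide to this swap. Going by the values given here, compound 1 at 1200 nM and compound 2 at 950 nM lie within the scatter of each other, and no measured step isolates the fluoro group. Among the compounds with values here, with no measured step at this position, no change beyond the scatter is expected in this assay, and the direction stays open.

The expected step is a 1.3-fold lower number from compound 3 to compound 4 (0.12 log units; within the scatter), and this is only an estimate. For compound 4 the estimated value is 140000 nM, with an expected range from 50000 nM to 350000 nM.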

Compound 4, half-maximal inhibitory concentration: 107000 nM
Compound 4: the middle estimate sits 1.3-fold (0.12 log units) above what was measured; the measured number falls inside the stated range.
By their numbers in this assay, from the lowest: compounds 2 and 1 (each within the scatter of the next); then compounds 4 and 3 (each within the scatter of the next).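

In this assay, for the compounds shown here, methyl in place of fluoro on an aromatic carbon, para to a large group, gives a 1.7-fold lower number from compound 3 to compound 4 (0.24 log units; within the scatter), and this is the first measured step at this position. The exchange keeps the same count of one heavy atom and leaves the number within the scatter, so on the background of compound 3, whose nitrogen carries only hydrogen, this read-out does not separate fluoro from methyl. No supporting evidence is available to explain why the two groups read alike here.

The compounds shown leave open whether fluoro and methyl would also read alike on the background of compound 1, where the nitrogen carries the (1-bromoethenyl)carbonyl group, as that compound has no methyl partner here. Going by these compounds alone, they also leave open how a quite different group at this position, such as a nitrile, an amine or a carboxylic acid, would compare, since fluoro and methyl are the only single groups here that can be compared directly at this position.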